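Replacing methyl with bromo in an antiproliferative series

This account rests on a few compounds, and the source may have more. Where it says the series, first, only, none or still open, it means among the compounds named here.

Compound 1 `Cc1ccc(NC(=O)C(C)Br)cc1C(=O)NC(N)=O` is the starting point. In a functional assay on CCRF-CEM cells (Homo sapiens) for antiproliferative activity, read by trypan blue exclusion, with a stated time of 72 h (on this read-out higher numbers stand for weaker inhibition and lower numbers for stronger inhibition), compound 1 gives > 20000 nM, which is a limit of the assay and not a number. Its true standing is therefore unknown.

Among the measured compounds shown here, compound 2 `CC(Br)C(=O)Nc1cc(C(=O)NC(N)=O)ccc1F` gives 3130 nM, the only actual number so far. No single-place step links compound 2 with compound 1, so this value shows only that a number can be obtained among these close relatives.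

Compound 3 `CC(Br)C(=O)Nc1ccc(Br)c(C(=O)NC(N)=O)c1` keeps the core of compound 1 but has bromo in place of methyl on an aromatic carbon, ortho to a carbamoylcarbamoyl group and para to a ((1-bromoethyl)carbonyl)amino group: bromo in place of methyl on an aromatic carbon.

For the measured compounds named here, no measured step covers this change, so any forecast is loose. Going by the values given here, a move toward stronger inhibition in this assay is expected, with compound 2 at 3130 nM as the only numerical guide. The expected change is an at least 5.0-fold lower number from compound 1 to compound 3 (0.69 log units; beyond the scatter). The estimated value for compound 3 is 4000 nM, with an expected range of 600 nM to 20000 nM.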

Compound 3, half-maximal inhibitory concentration: 7630 nM
Compound 3: the middle estimate sits 1.9-fold (0.28 log units) below what was measured; the measured number falls inside the stated range.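

Bromo in place of methyl on an aromatic carbon, ortho to a carbamoylcarbamoyl group and para to a ((1-bromoethyl)carbonyl)amino group, gives in this assay an at least 2.6-fold lower number from compound 1 to compound 3 (0.41 log units; beyond the scatter). This is the only single-place step among the compounds shown, and it shows that this one aromatic carbon can move the read-out toward stronger inhibition beyond the scatter while the rest of the core of compound 1 stays the same. The true size of the step remains unknown because compound 1 gives only a limit and not a number: the limit of > 20000 nM in this assay, at which 1 of the 3 values shown sits.

The compounds shown leave open how a hydrogen, a chloro group, a methoxy group or an amine on this same aromatic carbon would read, and so whether bromo itself matters or the loss of methyl is enough. They also leave open whether the same exchange would give a similar step on another carbon of the six-membered aromatic ring, or with a longer chain in place of the 1-bromoethyl part.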